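The Same Methoxy Change on Two Cores

The source may hold more compounds than are shown below. What is called first, only, known or untested is meant among the compounds shown, and "the series" means these compounds.

In a functional assay on NCI-H1299 cells (Homo sapiens) for antiproliferative activity, read by MTT assay, with a stated time of 24 h (on this read-out higher numbers stand for weaker inhibition and lower numbers for stronger inhibition), three compounds have been measured:

compound 1 `O=C(/C=C/c1ccc(O)c(O)c1)NNC(=O)c1ccccc1`, 6770 nM
compound 2 `COc1ccc(C(=O)NNC(=O)/C=C/c2ccc(O)c(O)c2)cc1`, 5420 nM
compound 3 `COc1cc(/C=C/C(=O)NNC(=O)c2ccccc2)cc(OC)c1O`, > 10000 nM

Compound 2 differs from compound 1 by methoxy in place of hydrogen on an aromatic carbon. That change produced a 1.2-fold lower number from compound 1 to compound 2 (0.10 log units; within the scatter). For compound 3 the reported value is not a number but (the limit of > 10000 nM in this assay, at which 1 of the 3 values shown sits). The difference between the core of compound 1 and the core of compound 3 is not broken down here.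

Compound 4 `COc1ccc(C(=O)NNC(=O)/C=C/c2cc(OC)c(O)c(OC)c2)cc1` has not yet been measured in this assay. It differs from compound 3 by methoxy in place of hydrogen on an aromatic carbon, the same change as that between compound 1 and compound 2. The earlier step was a 1.2-fold lower number from compound 1 to compound 2 (0.10 log units; within the scatter). On that basis the expected step is a step that the limit leaves unreadable from compound 3 to compound 4, small and within the usual scatter. Because compound 3 itself sits at the limit of > 10000 nM in this assay, at which 1 of the 3 values shown sits, compound 4 is expected to give only a limit again rather than a number. Compound 4 is estimated at 14000 nM, with a likely range from 7000 nM to 40000 nM.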

Compound 4, half-maximal inhibitory concentration: 7450 nM
Beside the measured number, compound 4's estimate is 1.9-fold (0.27 log units) above it; the range from low to high includes it.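

In this assay, the change from phenyl to 4-methoxyphenyl gave an at least 1.3-fold lower number from compound 3 to compound 4 (0.12 log units; that floor lies within the scatter), while on the core of compound 1 the same change gave a 1.2-fold lower number from compound 1 to compound 2 (0.10 log units; within the scatter). Set side by side, the two cores compare as follows: the same change on two cores in this assay, a 1.2-fold lower number (0.10 log units; within the scatter) from compound 1 to compound 2 and an at least 1.3-fold lower number (0.12 log units; that floor lies within the scatter) from compound 3 to compound 4; the limit leaves it open whether they differ Compound 3 carries only a limit, > 10000 nM, and not a number, so the second step has a floor but no measured size, and the series shows neither that the change carries over with the same size nor that its size depends on the core.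

The compounds shown leave open whether a different group on the same aromatic carbon, such as an amine or a carboxylic acid, would give a step beyond the scatter on either core. For the compounds shown here, they also leave open how the methoxy change would read on a third core, since only two pairs bear on it here.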